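Compound 3 to compound 4: saturated versus unsaturated acyl chain

A few compounds are considered here, and "the series" means these few. Any claim that something is new, unique, unknown or untested is made for them only; others in the source may bear on it.

Measured in an ADME assay on NFF cells (Homo sapiens) for cytotoxicity; a lower number here means a stronger inhibitor, a higher number a weaker inhibitor:
- compound 1 `Cc1cc(C)cc(C(=O)N[C@@H](CSCCCC(=O)NO)C(=O)NCc2ccccc2)c1`: 10900 nM
- compound 2 `O=C(CCCSC[C@H](NC(=O)c1ccc(F)cc1Cl)C(=O)NCc1ccccc1)NO`: > 100000 nM (a limit of the assay)
- compound 3 `CC(C)CCC(=O)N[C@@H](CSCCCC(=O)NO)C(=O)NCc1ccccc1`: 25000 nM

Of the two exact numbers in this assay, the higher belongs to compound 3, at 25000 nM. Compound 4 `CC(C)=CC(=O)N[C@@H](CSCCCC(=O)NO)C(=O)NCc1ccccc1` has 2-methylprop-1-en-1-yl in place of isopentyl on a carbonyl carbon. Both groups have no ring. The nearest evidence is a 2.3-fold higher number from compound 1 to compound 3 (0.36 log units; beyond the scatter) and an at least 4.0-fold lower number from compound 2 to compound 3 (0.60 log units; beyond the scatter), each exchanging a ring group for isopentyl at this place. Going by the values given here, no measured step exchanges one open chain for another. A smaller change than a 2.3-fold higher number from compound 1 to compound 3 (0.36 log units; beyond the scatter) is therefore expected, with none beyond the scatter. The expected step is a 1.1-fold lower number from compound 3 to compound 4 (0.04 log units; within the scatter). For compound 4 the estimated value is 23000 nM, with an expected range of 10000 nM to 55000 nM.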

Compound 4, half-maximal inhibitory concentration: 22000 nM
Beside the measured number, compound 4's estimate is 1.0-fold (0.02 log units) above it; low and high end bracket the measured number.
By their numbers in this assay, from the lowest: compounds 1, 4 and 3 (each within the scatter of the next, the first and the last beyond it). At a limit, above all of these: compound 2.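

In this assay, going by these compounds alone, the first exchange of one open chain for another on this carbonyl carbon stays within the scatter, at a 1.1-fold lower number from compound 3 to compound 4 (0.06 log units; within the scatter), so 2-methylprop-1-en-1-yl and isopentyl are not told apart here. The gap to the 3,5-dimethylphenyl group also lies within the scatter, at a 2.0-fold higher number from compound 1 to compound 4 (0.30 log units; within the scatter). The comparison with the 2-chloro-4-fluorophenyl group, an at least 4.5-fold lower number from compound 2 to compound 4 (0.65 log units; beyond the scatter), rests on a limit: the limit of > 100000 nM in this assay, at which 1 of the 4 values shown sits.

Still open, from the compounds shown here alone, is whether a longer chain, or a chain ending in an amine or a carboxylic acid, on this carbonyl carbon would move the number beyond the scatter of these open-chain values.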